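Bromo in place of hydrogen on compound 3

The source may report more compounds than this note shows. Statements on the series, on what has been measured and on what is new or still open speak of the compounds shown alone.

Measured in a functional assay on thoracic aorta (Rattus norvegicus, strain Wistar), with a stated time of 15 min; a higher number here means that more compound is needed for the effect, a lower number that less compound is needed:
- compound 1 `CC(C)Oc1ccc(Br)cc1C(C)NC(=O)N(C)S(=O)(=O)c1ccccc1`: 32100 nM
- compound 2 `Cc1ccc(S(=O)(=O)N(C)C(=O)NC(C)c2cc(Br)ccc2OCc2ccccc2)cc1`: 67100 nM
- compound 3 `CC(NC(=O)N(C)S(=O)(=O)c1ccccc1)c1ccccc1OCc1ccccc1`: 21700 nM

Compound 3 at 21700 nM lies within the scatter of compound 1 at 32100 nM. Compound 2 at 67100 nM stands at a higher number than compound 3, beyond the scatter.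

Compound 4 `CC(NC(=O)N(C)S(=O)(=O)c1ccccc1)c1cc(Br)ccc1OCc1ccccc1` differs from compound 3 by bromo in place of hydrogen on an aromatic carbon, para to a benzyloxy group. Going by the values given here, no measured pair isolates this change. Compound 1 at 32100 nM and compound 2 at 67100 nM both carry bromo but differ elsewhere, so only a small move towards a higher number is expected. The expected change is a 1.6-fold higher number from compound 3 to compound 4 (0.21 log units; within the scatter). For compound 4 the estimated value is 35000 nM, with an expected range of 15000 nM to 80000 nM.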

Compound 4, half-maximal effective concentration: 60300 nM
Compound 4: the middle estimate sits 1.7-fold (0.24 log units) below what was measured; low and high end bracket the measured number.
By their numbers in this assay, from the lowest: compounds 3, 1, 4 and 2 (each within the scatter of the next, the first and the last beyond it).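

In this assay, going by these compounds alone, bromo in place of hydrogen, para to a benzyloxy group, gives a 2.8-fold higher number from compound 3 to compound 4 (0.44 log units; beyond the scatter) and is the first isolated reading of this change. With bromo in place, hydrogen in place of methyl on an aromatic carbon gives a 1.1-fold lower number from compound 2 to compound 4 (0.05 log units; within the scatter) and benzyl in place of isopropyl on the oxygen gives a 1.9-fold higher number from compound 1 to compound 4 (0.27 log units; within the scatter) and so, of these three single changes, only the bromo step lies beyond the scatter. No available evidence bears on the origin of the bromo step. As far as these compounds go, whether chloro, methoxy or an amine at this position would match bromo stays open.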